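The compounds below may be only part of what the source reports. "The series", "measured", "known", "first", "only" and "open" are said of these compounds alone.

Of the compounds shown here, three have so far been measured in an assay for inhibition of 15-hydroxyprostaglandin dehydrogenase [NAD(+)] (Homo sapiens), read by fluorescence, with a stated time of 15 min, in the presence of a further agent that is not named here; on this read-out higher numbers stand for weaker inhibition and lower numbers for stronger inhibition. Compound 1 `Nc1c([S+]([O-])CCCCl)sc2nc(-c3cccs3)cc(-c3ccccc3)c12` gives 4 nM, compound 3 `CCCC[S+]([O-])c1sc2nc(-c3ncco3)cc(-c3ccccc3)c2c1N` gives 1.4 nM in this assay, and compound 2 `CCCC[S+]([O-])c1nc2ccc(-c3cccs3)nc2s1` gives 1230 nM. Compound 1 thus holds the second highest of the three numbers, with compound 3 lower by a margin beyond the scatter and compound 2 higher by a margin far beyond it. Compound 4 `CCCCS(=O)(=O)c1sc2nc(-c3cccs3)cc(-c3ccccc3)c2c1N` differs from compound 1 in one place: a group of 7 heavy atoms (4 carbon, 2 oxygen, 1 sulfur; no ring) in place of a group of 6 heavy atoms (3 carbon, 1 oxygen, 1 sulfur, 1 chlorine; no ring), on an aromatic carbon. Going by the values given here, no measured pair isolates this change, so the step in this assay is expected to be small, drifting slightly toward a higher number. Compound 4 is therefore estimated at 6 nM, within a range from 1.5 nM to 25 nM. This expectation corresponds to a step of a 1.5-fold higher number from compound 1 to compound 4 (0.18 log units; within the scatter).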

Compound 4, half-maximal inhibitory concentration: 25 nM
Compound 4: the middle estimate sits 4.2-fold (0.62 log units) below what was measured, and the stated range covers the measured number.
By their numbers in this assay, from the lowest: compound 3; then compound 1; then compound 4; then compound 2.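

In this assay, going by these compounds alone, the aromatic carbon next to the ring sulfur proves sensitive to what it carries: butylsulfonyl in place of the chlorine-bearing group of compound 1 gives a 6.3-fold higher number from compound 1 to compound 4 (0.80 log units; beyond the scatter), a modest weakening that no earlier pair could show. The swap changes the chain, the chlorine and the oxygen count together, so the step cannot be assigned to any one of them. Nothing available here explains the step.

From the compounds shown here alone, whether a chlorine-bearing sulfonyl chain, a longer chain, or an amine or carboxylic acid on this carbon would keep the inhibition remains open.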